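Adding a Second Methoxy to Compound 1

This account rests on a few compounds, and the source may have more. Where it says the series, first, only, none or still open, it means among the compounds named here.

Among the measured compounds shown here, in a functional assay on LoVo cells (Homo sapiens) for inhibition, read by MTT assay, with a stated time of 72 h (on this read-out lower numbers stand for stronger inhibition and higher numbers for weaker inhibition), compound 1 (`C=C(Br)C(=O)Nc1cccc(/C=C/C(=O)Nc2ccc(OC)cc2)c1`) gives 550 nM and compound 2 (`C=C(Br)C(=O)Nc1cccc(/C=C/C(=O)Nc2ccc(OCC)cc2)c1`) gives 850 nM as the only other number, so compound 1 stands level with its one neighbour. Compound 3 (`C=C(Br)C(=O)Nc1cccc(/C=C/C(=O)Nc2ccc(OC)c(OC)c2)c1`) carries one change from compound 1 (methoxy in place of hydrogen on an aromatic carbon): methoxy in place of hydrogen on an aromatic carbon, ortho to a methoxy group. For the measured compounds named here, the one measured step that bears on it, a 1.5-fold higher number from compound 1 to compound 2 (0.19 log units; within the scatter) for methyl in place of hydrogen on a saturated chain carbon bound to an oxygen on an aromatic ring, stayed within the scatter. No step beyond the scatter is therefore expected in this assay (estimated: a 1.1-fold higher number from compound 1 to compound 3 (0.04 log units; within the scatter) in all). Compound 3 is expected at 600 nM with an estimated range from 250 nM to 1500 nM for now.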

Compound 3, half-maximal inhibitory concentration: 150 nM
Compound 3: the middle estimate sits 4.0-fold (0.60 log units) above what was measured, and the stated range ends above it.
By their numbers in this assay, from the lowest: compound 3; then compounds 1 and 2 (each within the scatter of the next).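

In this assay, this aromatic carbon, ortho to a methoxy group, responds to substitution: methoxy in place of hydrogen gives a 3.7-fold lower number from compound 1 to compound 3 (0.56 log units; beyond the scatter). The earlier change, made on the chain bound to the oxygen, gave only a 1.5-fold higher number from compound 1 to compound 2 (0.19 log units; within the scatter), so this is the first step shown that clearly moves the number, here towards stronger inhibition. Nothing measured here explains why this methoxy has this effect. From the compounds shown here alone, whether a hydroxy group, an amine or a fluorine atom on this same carbon would give a similar number remains open.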